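From 2-hydroxyethyl to benzyl: one swap, one limit

A few compounds are considered here, and "the series" means these few. Any claim that something is new, unique, unknown or untested is made for them only; others in the source may bear on it.

Compound 1 (`N[C@H]1CC[C@H](Nc2c(C(=O)NCc3ccc(F)cc3)nc(N3CCCCC3)c3cccnc23)CC1`) gives 8500 nM
Compound 2 (`O=C(NCc1ccc(F)cc1)c1nc(Br)c2cccnc2c1NCCO`) gives > 20000 nM
Compound 3 (`C[C@H](CO)Nc1nc(C(=O)NCc2ccc(F)cc2)c(O)c2ncccc12`) gives "not determined" (no result reported)

In a functional assay on HCT-116 cells (Homo sapiens) for cytotoxicity, read by MTT assay, with a stated time of 72 h (a higher number here means a weaker inhibitor, a lower number a stronger inhibitor), compound 2 gives > 20000 nM as a limit and not as a number.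

Only compound 1 has a plain number, 8500 nM in this reading, while the entry for compound 3 is "not determined" (no result reported) and offers no guide.

Compound 4 (`O=C(NCc1ccc(F)cc1)c1nc(Br)c2cccnc2c1NCc1ccccc1`) keeps compound 2 intact except for one change on the amino side chain. There, 2-hydroxyethyl becomes benzyl, which means phenyl in place of hydroxymethyl on a saturated chain carbon bound to a nitrogen on an aromatic ring.

Among the measured compounds shown here, no measured pair shows what such a swap does, so any forecast here is loose. Compound 1 at 8500 nM suggests that a number can be read for compounds of this kind, although it differs from compound 2 in more than one place. A modest move toward a stronger inhibitor is expected, and the estimated change is an at least 1.6-fold lower number from compound 2 to compound 4 (0.22 log units; that floor lies within the scatter) with another limit reading still quite possible. In this assay the estimate for compound 4 is 12000 nM with 4000 nM to 30000 nM as the expected range.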

Compound 4, half-maximal inhibitory concentration: > 20000 nM
Compound 4: only a limit was reported; the forecaster's own chance of this, stated with the estimate: 45%; at least 1.6-fold (0.22 log units) between middle value and limit.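

In this assay compound 2 and compound 4 both stop at the same limit and give no plain number, so no step between them can be read: the limit of > 20000 nM in this assay, at which 2 of the 4 values shown sit.

From the compounds shown here alone, what the swap of hydroxymethyl for phenyl does to cell killing in this pair stays open.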